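Same Aryl Swap on Two Cores, Against an Assay Limit

This account rests on a few compounds, and the source may have more. Where it says the series, first, only, none or still open, it means among the compounds named here.

In a functional assay on MDA-MB-231 cells (Homo sapiens) for cytotoxicity, read by MTT assay, with a stated time of 48 h (a higher number here means a weaker inhibitor, a lower number a stronger inhibitor), compound 1 `Cc1ccc(NC(=O)NCCCCC(c2ccc(F)cc2)c2ccc(F)cc2)cc1C` gives > 20000 nM, which is a limit of the assay and not a number.
In this assay compound 2 `O=C(NCCCCC(c1ccc(F)cc1)c1ccc(F)cc1)Nc1ccc(Br)cc1I` gives > 20000 nM, again a limit and not a number.
In this assay compound 3 `Cc1ccc(NC(=O)NCCCCN(c2ccc(F)cc2)c2ccc(F)cc2)cc1C` gives > 20000 nM, also a limit and not a number.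

Compound 2 differs from compound 1 by 4-bromo-2-iodophenyl in place of 3,4-dimethylphenyl on an amide-type nitrogen. The step that the two limits leave unreadable from compound 1 to compound 2 cannot be read, since the limit of > 20000 nM in this assay, at which 3 of the 3 values shown sit, covers both ends of it. Compound 3 carries a different core from compound 1; that difference is not broken down here.

Compound 4 `O=C(NCCCCN(c1ccc(F)cc1)c1ccc(F)cc1)Nc1ccc(Br)cc1I` has not been measured in this assay. It stands to compound 3 exactly as compound 2 stands to compound 1, through the same change, (4-bromo-2-iodophenyl in place of 3,4-dimethylphenyl on an amide-type nitrogen), at the same place. The step from compound 3 to compound 4 is expected to be a step that the limit leaves unreadable from compound 3 to compound 4, an expectation that rests on the limit of > 20000 nM in this assay, at which 3 of the 3 values shown sit, and on the unreadable step that the two limits leave unreadable from compound 1 to compound 2, nothing more. Compound 4 is therefore expected to give 30000 nM in this assay, within a range of 12000 nM to 100000 nM, most likely again as a limit rather than a number.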

Compound 4, half-maximal inhibitory concentration: > 20000 nM
Compound 4 was reported as a limit; the forecaster's own chance of this, stated with the estimate: 85%; the middle value does not contradict the limit.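

No new step can be read for compound 3 and compound 4, since both sit at a limit of the assay and not at a number, which leaves the effect of their aryl swap unreadable: the limit of > 20000 nM in this assay, at which 4 of the 4 values shown sit.

The compounds shown leave open how strongly any of the four acts, and whether 4-bromo-2-iodophenyl in place of 3,4-dimethylphenyl changes the read-out at all on either core.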